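Furan substitution pattern at the chain carbon: compound 4

The compounds below may be only part of what the source reports. "The series", "measured", "known", "first", "only" and "open" are said of these compounds alone.

Among the measured compounds shown here, compound 3 `CCc1ccoc1[C@@H](CC)Nc1c(Nc2cccc(C(=O)N(C)C)c2O)c(=O)c1=O` gives 379 nM in an assay on CHO cells for displacement of a labelled ligand from C-X-C chemokine receptor type 1 (Homo sapiens) (a higher number here means a weaker inhibitor, a lower number a stronger inhibitor), and so holds the highest number of the three measured members, above compound 1 `CC[C@@H](Nc1c(Nc2cccc(C(=O)N(C)C)c2O)c(=O)c1=O)c1ccc(C)s1` at 146 nM and far above compound 2 `CC[C@@H](Nc1c(Nc2cccc(C(=O)N(C)C)c2O)c(=O)c1=O)c1cc(C)co1` at 9 nM. The move to compound 4 `CC[C@@H](Nc1c(Nc2cccc(C(=O)N(C)C)c2O)c(=O)c1=O)c1cc(C(C)C)co1` is 4-isopropylfuran-2-yl in place of 3-ethylfuran-2-yl on a saturated chain carbon bound to a nitrogen on an aromatic ring and a saturated chain carbon. The entering group resembles the 4-methylfuran-2-yl of compound 2, with isopropyl standing where methyl stood. For the measured compounds named here, two measured steps bear on this. The step of a 42-fold higher number from compound 2 to compound 3 (1.62 log units; beyond the scatter) shows that shifting the alkyl from 4-methylfuran-2-yl to 3-ethylfuran-2-yl costs a great deal, so the reverse move should regain most of it. The steps of a 16-fold lower number from compound 1 to compound 2 (1.21 log units; beyond the scatter) and a 2.6-fold higher number from compound 1 to compound 3 (0.41 log units; beyond the scatter) confirm that the 4-methylfuran-2-yl arrangement sits well below the thiophene and the 3-ethylfuran-2-yl arrangement above it. Going by the values given here, no measured pair tells how isopropyl compares with methyl on the furan, so that part of the change is left open and widens the range. A large drop in this assay is therefore expected for compound 4, with the step estimated as a 15-fold lower number from compound 3 to compound 4 (1.18 log units; beyond the scatter). Compound 4 is expected to give 25 nM in this assay, within a range from 6 nM to 120 nM.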

Compound 4, inhibition constant: 3 nM
Beside the measured number, compound 4's estimate is 8.3-fold (0.92 log units) above it; the measured number lies below the stated range.
By their numbers in this assay, from the lowest: compound 4; then compound 2; then compound 1; then compound 3.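

In this assay, among the compounds shown here, isopropyl in place of methyl gives a 3.0-fold lower number from compound 2 to compound 4 (0.48 log units; beyond the scatter) and is the first measured read on the size of the alkyl group on the furan: going from methyl to isopropyl lowers the number rather than raising it, and compound 4 now has the lowest number of the four, with each of its steps printed as beyond the scatter. The 4-isopropylfuran-2-yl group also opens the widest gap in the set, a 130-fold lower number from compound 3 to compound 4 (2.10 log units; beyond the scatter), and extends the lead of the furans with a 4-alkyl group over the 5-methylthiophen-2-yl group of compound 1, with a 49-fold lower number from compound 1 to compound 4 (1.69 log units; beyond the scatter), so the choice of group on this saturated chain carbon moves the number strongly in both directions. Nothing in the data shown accounts for the gain from isopropyl.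

As far as these compounds go, whether the number keeps falling with further growth of the alkyl group remains open, for example with a tert-butyl, a cyclopropyl or a longer chain in place of the isopropyl. Also open, from the compounds shown here alone, is how much of the gap between compound 3 and the other furans belongs to the place of the alkyl group and how much to the alkyl group itself, a question that 3-methylfuran-2-yl and 4-ethylfuran-2-yl groups would separate.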